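Replacing a Piperidinyl Ether With an Open Amino Alcohol

The compounds below may be only part of what the source reports. "The series", "measured", "known", "first", "only" and "open" are said of these compounds alone.

In a physicochemical assay for solubility, read by nephelometry, measured as kinetic solubility, with a stated time of 30 min (a lower number here means a less soluble compound, a higher number a more soluble compound), compound 1 (`NCCOc1ccc([C@H]2CC[C@]3(CC2)OOC2(O3)C3CC4CC(C3)CC2C4)cc1`) reads > 100 ug/mL, which is a limit of the assay and not a number. For the measured compounds named here, compound 2 (`c1cc([C@H]2CC[C@]3(CC2)OOC2(O3)C3CC4CC(C3)CC2C4)ccc1OCCOC1CCNCC1`) gives 50 ug/mL, the only true number so far. Compound 3 (`CC(C)(O)CNCCCOc1ccc([C@H]2CC[C@]3(CC2)OOC2(O3)C3CC4CC(C3)CC2C4)cc1`) differs from compound 2 by ((2-hydroxy-2-methylpropyl)amino)methyl in place of (piperidin-4-yl)oxy on a saturated chain carbon, two bonds along the chain from an oxygen on an aromatic ring. The incoming group has no ring. Going by the values given here, one measured step bears on this change: an at least 2.0-fold lower number from compound 1 to compound 2 (0.30 log units; that floor lies within the scatter), a floor within the scatter that rests on (the limit of > 100 ug/mL in this assay, at which 1 of the 2 values shown sits). Since that step, an at least 2.0-fold lower number from compound 1 to compound 2 (0.30 log units; that floor lies within the scatter), shows nothing beyond the scatter, no step beyond the scatter is expected in this assay. The expected change is a 1.2-fold higher number from compound 2 to compound 3 (0.08 log units; within the scatter). For compound 3 the estimated value is 60 ug/mL, with an expected range of 25 ug/mL to 100 ug/mL.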

Compound 3, solubility: > 100 ug/mL
Compound 3 ended at the assay's limit; the forecaster's own chance of this, stated with the estimate: 20%; middle value at least 1.6-fold (0.22 log units) away from the limit.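

In this assay compound 3 gives > 100 ug/mL, which is a limit of the assay and not a number. On a saturated chain carbon, two bonds along the chain from an oxygen on an aromatic ring, a group with no ring and an equal count of heavy atoms replaces (piperidin-4-yl)oxy, giving an at least 2.0-fold higher number from compound 2 to compound 3 (0.30 log units; that floor lies within the scatter), so this floor, like the earlier one, shows nothing beyond the scatter. The step from compound 1 to compound 3 cannot be read, and the top of the scale now bounds what this position can show: the limit of > 100 ug/mL in this assay, at which 2 of the 3 values shown sit.

The compounds shown do not separate the loss of the piperidine ring from the loss of the ether oxygen. On these data alone, whether a morpholine or a carboxylic acid at this place would read as a true number also remains open.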